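The compounds below may be only part of what the source reports. "The series", "measured", "known", "first", "only" and "open" are said of these compounds alone.

In a functional assay on BXPC-3 cells (Homo sapiens) for antiproliferative activity, read by MTT assay, with a stated time of 24 h (on this read-out higher numbers stand for weaker inhibition and lower numbers for stronger inhibition), compound 1 `CCn1c(C(=O)NC(C)(C)CO)ccc1C(CC)(CC)c1ccc(OCS(=O)(=O)c2ccccc2)c(C)c1` gives 18300 nM, compound 2 `CCn1c(C(=O)N[C@@H](CO)CCCO)ccc1C(CC)(CC)c1ccc(OCS(=O)(=O)c2ccccc2)c(C)c1` gives 16400 nM and compound 3 `CCn1c(C(=O)N[C@@H](C)C(=O)O)ccc1C(CC)(CC)c1ccc(OCS(=O)(=O)c2ccccc2)c(C)c1` gives 20800 nM. Compound 3 thus stands level with the other two, all three lying within the scatter of one another.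

The next change leads to compound 4 `CCn1c(C(=O)N[C@H](CC(=O)O)C(=O)O)ccc1C(CC)(CC)c1ccc(OCS(=O)(=O)c2ccccc2)c(C)c1`: 1,2-dicarboxyethyl in place of 1-carboxyethyl on an amide-type nitrogen. In words, 1,2-dicarboxyethyl comes in place of 1-carboxyethyl on an amide-type nitrogen.

The measured steps that bear on this are those at the same nitrogen: a 1.1-fold higher number from compound 1 to compound 3 (0.06 log units; within the scatter), a 1.3-fold higher number from compound 2 to compound 3 (0.10 log units; within the scatter) and a 1.1-fold lower number from compound 1 to compound 2 (0.05 log units; within the scatter). Each lies within the scatter, and that includes both steps that end at the 1-carboxyethyl group of compound 3. No side chain measured so far is a 1,2-dicarboxyethyl, so the evidence is indirect. On these steps, no change beyond the scatter is expected in this assay.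

The estimated step is a 1.0-fold higher number from compound 3 to compound 4 (0.00 log units; within the scatter). Compound 4 is estimated at 21000 nM, with an expected range of 11000 nM to 42000 nM.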

Compound 4, half-maximal inhibitory concentration: > 50000 nM
Compound 4 ended at the assay's limit; the forecaster's own chance of this, stated with the estimate: 15%; middle value at least 2.3-fold (0.37 log units) away from the limit.
By their numbers in this assay, from the lowest: compounds 2, 1 and 3 (each within the scatter of the next). At a limit, above all of these: compound 4.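

In this assay compound 4 gives > 50000 nM, a limit of the assay and not a number. The amide-type nitrogen, which showed no change beyond the scatter among the earlier side chains, does respond to this group: 1,2-dicarboxyethyl in place of 1-carboxyethyl gives an at least 2.4-fold higher number from compound 3 to compound 4 (0.38 log units; beyond the scatter), and the comparisons with the two hydroxyl-bearing side chains give an at least 3.0-fold higher number from compound 2 to compound 4 (0.48 log units; beyond the scatter) and an at least 2.7-fold higher number from compound 1 to compound 4 (0.43 log units; beyond the scatter). All three steps are lower bounds, and they rest on a single value at the limit: the limit of > 50000 nM in this assay, at which 1 of the 4 values shown sits.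

As far as these compounds go, the full size of the step stays open, and these compounds do not separate the second carboxylic acid from the added chain length. From the compounds shown here alone, how an amine or a primary amide at that chain end would read also stays open, as does a longer chain carrying both carboxylic acids.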